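Chloro to Methoxy on a Thiazolyl Ketone Thioether Series

A few compounds are considered here, and "the series" means these few. Any claim that something is new, unique, unknown or untested is made for them only; others in the source may bear on it.

Compound 1 `COc1ccc(-c2nc(C)c(C(=O)CSc3nc(-c4ccc(OC)cc4)c(C#N)c(=O)[nH]3)s2)cc1` and compound 2 `COc1ccc(-c2nc(SCC(=O)c3sc(-c4ccc(Cl)cc4)nc3C)[nH]c(=O)c2C#N)cc1` share a core and differ in one place, (methoxy in place of chloro on an aromatic carbon). In a functional assay on U-87MG ATCC cells for antiproliferative activity against U-87 MG (Homo sapiens), read by MTT assay, with a stated time of 48 h (on this read-out lower numbers stand for stronger inhibition and higher numbers for weaker inhibition), compound 2 gives 35500 nM and compound 1 gives 25300 nM, a step of a 1.4-fold lower number from compound 2 to compound 1 (0.15 log units; within the scatter). Compound 3 `Cc1nc(-c2ccc(Cl)cc2)sc1C(=O)CSc1nc(N)c(C#N)c(-c2ccc(Cl)cc2)n1` has a different core; the difference between the two cores is not broken down here. In this assay compound 3 gives 3420 nM, the lowest number of the three. Compound 4 `COc1ccc(-c2nc(SCC(=O)c3sc(-c4ccc(Cl)cc4)nc3C)nc(N)c2C#N)cc1` is made from compound 3 by the same change seen between compound 2 and compound 1, (methoxy in place of chloro on an aromatic carbon). Since the earlier step was within the scatter, the step is expected to be about a 1.1-fold lower number from compound 3 to compound 4 (0.06 log units; within the scatter). Compound 4 is therefore estimated to give about 3000 nM in this assay, with a likely range from 1200 nM to 8000 nM.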

Compound 4, half-maximal inhibitory concentration: 10600 nM
The estimate for compound 4 lay 3.5-fold (0.55 log units) below the measured number, outside the stated range (above it).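

In this assay, putting 4-methoxyphenyl in place of 4-chlorophenyl brings a 3.1-fold higher number from compound 3 to compound 4 (0.49 log units; beyond the scatter), so the size of this change on one core cannot be assumed on the other. The two steps differ by more than the scatter allows: the same change on two cores in this assay, a 1.4-fold lower number (0.15 log units; within the scatter) from compound 2 to compound 1 and a 3.1-fold higher number (0.49 log units; beyond the scatter) from compound 3 to compound 4, 4.3-fold (0.64 log units) apart, beyond the scatter of two such steps This does not show that the core alone sets the outcome, since the changed ring is not the same one in the two pairs, and two pairs cannot separate core from site.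

The compounds shown leave open how a smaller or different group in place of chloro, such as fluoro, methyl or dimethylamino, would behave on the core of compound 3. Also open, as far as these compounds go, is what methoxy on the remaining 4-chlorophenyl of compound 4 would do.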